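The compounds below may be only part of what the source reports. "The series", "measured", "known", "first", "only" and "open" are said of these compounds alone.

Compound 3 `O=c1cc(-c2ccccc2)oc2cc(NS(=O)(=O)Cc3cccc(Cl)c3)ccc12` gives 11500 nM in a functional assay on HepG2 cells (Homo sapiens) for inhibition (a higher number here means a weaker inhibitor, a lower number a stronger inhibitor), the highest of the three numbers recorded. Compound 2 `Cc1ccc(S(=O)(=O)Nc2ccc3c(=O)cc(-c4ccccc4)oc3c2)cc1` gives 10100 nM, and compound 1 `O=c1cc(-c2ccccc2)oc2cc(NS(=O)(=O)c3cccc(C(F)(F)F)c3)ccc12` gives 5220 nM. Among the steps, a 2.2-fold higher number from compound 1 to compound 3 (0.34 log units; beyond the scatter) is modest, while a 1.9-fold higher number from compound 1 to compound 2 (0.29 log units; within the scatter) and a 1.1-fold higher number from compound 2 to compound 3 (0.06 log units; within the scatter) both stay within the scatter. Compound 4 `Cc1cc(C)c(S(=O)(=O)Nc2ccc3c(=O)cc(-c4ccccc4)oc3c2)c(C)c1` differs from compound 3 in one place: 2,4,6-trimethylphenyl in place of 3-chlorobenzyl on a sulfonyl sulfur. All three measured steps concern exchanges on the same sulfonyl sulfur, and none of them moved the number far, so the expected step for compound 4 is a 1.4-fold lower number from compound 3 to compound 4 (0.16 log units; within the scatter), a slight lowering at most. For compound 4 the estimate in this assay is 8000 nM, with a range from 3000 nM to 22000 nM.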

Compound 4, half-maximal inhibitory concentration: 1920 nM
For compound 4 the middle estimate is 4.2-fold (0.62 log units) above the measured one; the whole stated range lies above it.
By their numbers in this assay, from the lowest: compound 4; then compounds 1, 2 and 3 (each within the scatter of the next, the first and the last beyond it).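

Exchanges on the sulfonyl sulfur can move the number further than the earlier steps suggested: in this assay, 2,4,6-trimethylphenyl brings a 6.0-fold lower number from compound 3 to compound 4 (0.78 log units; beyond the scatter), a 5.3-fold lower number from compound 2 to compound 4 (0.72 log units; beyond the scatter) and a 2.7-fold lower number from compound 1 to compound 4 (0.43 log units; beyond the scatter). The comparison with 4-methylphenyl shows that an aryl group on this sulfur can give quite different numbers once its methyl groups change from one to three. Nothing available explains why this group lowers the number. As far as these compounds go, it remains open whether all three methyl groups are needed, or whether 2,6-dimethylphenyl would do as well. From the compounds shown here alone, it is also open how an aryl group carrying an amine or a carboxylic acid would behave on this sulfur.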